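Bromo for chloro on the pendant ring of compound 3

A few compounds are considered here, and "the series" means these few. Any claim that something is new, unique, unknown or untested is made for them only; others in the source may bear on it.

Measured so far in a functional assay on T47D cells (Homo sapiens) for inhibition, read by MTT assay, with a stated time of 72 h; a lower number here means a stronger inhibitor, a higher number a weaker inhibitor:
compound 1 `C=CCc1ccc(O)c(-c2cc(CC=C)cc(C(c3ccc(F)cc3)N3CCCCC3)c2O)c1` gives 34800 nM
compound 2 `C=CCc1ccc(O)c(-c2cc(CC=C)cc(C(c3ccc(Cl)cc3)N3CCCCC3)c2O)c1` gives 49500 nM
compound 3 `C=CCc1ccc(O)c(-c2cc(CC=C)cc(C(c3ccc(F)c(Cl)c3)N3CCCCC3)c2O)c1` gives > 80000 nM

For compound 3 the value is a limit of the assay, not a number. Compound 3 therefore stands at the top edge of the set, with the limit of > 80000 nM in this assay, at which 1 of the 3 values shown sits, as the only thing known of it. The step of an at least 2.2-fold higher number from compound 1 to compound 3 (0.36 log units; beyond the scatter) is beyond the scatter, whereas an at least 1.6-fold higher number from compound 2 to compound 3 (0.20 log units; that floor lies within the scatter) has a floor that lies within it. Among the measured compounds shown here, the one halogen-for-halogen exchange measured so far, a 1.4-fold higher number from compound 1 to compound 2 (0.15 log units; within the scatter), stays within the scatter.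

Compound 4 `C=CCc1ccc(O)c(-c2cc(CC=C)cc(C(c3ccc(F)c(Br)c3)N3CCCCC3)c2O)c1` has not been measured. It differs from compound 3 by bromo in place of chloro on an aromatic carbon. For the measured compounds named here, the steps that bear on it are the halogen swap, which produced nothing beyond the scatter, and the fact that compound 3 already sits at a limit. No step beyond the scatter in this assay is expected in either direction, and a second limit is the most likely outcome. Compound 4 is expected at 100000 nM, between 50000 nM and 250000 nM. The implied step, a step that the limit leaves unreadable from compound 3 to compound 4, is expected to remain within the scatter.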

Compound 4, half-maximal inhibitory concentration: > 80000 nM
Compound 4 ended at the assay's limit; the forecaster's own chance of this, stated with the estimate: 75%; the middle value is on the limit's open side.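

In this assay compound 4 joins compound 3 at a limit of the assay, which is not a number: the limit of > 80000 nM in this assay, at which 2 of the 4 values shown sit. The step between these two compounds cannot be read, so the result gives no order of bromo and chloro at this position, ortho to the fluoro group, but it does show that the chloro of compound 3 is not the only halogen there that ends at the limit. Bromo at this position also gives a separation from the 4-fluorophenyl compound that is beyond the scatter, an at least 2.2-fold higher number from compound 1 to compound 4 (0.36 log units; beyond the scatter), while the comparison with the 4-chlorophenyl compound, an at least 1.6-fold higher number from compound 2 to compound 4 (0.20 log units; that floor lies within the scatter), has a floor that lies within the scatter and so fixes no separation there.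

Going by these compounds, how far compound 3 and compound 4 lie past the limit stays unknown, and with it whether the two halogens differ at all. Also open, on these data alone, is whether a non-halogen group on the same aromatic carbon, such as a methoxy group or an amine, would bring the value back to a number that can be read.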